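This account rests on a few compounds, and the source may have more. Where it says the series, first, only, none or still open, it means among the compounds named here.

Within the data shown here, compound 2 `FC(F)(F)c1cc(NC[C@H]2CCCCN2)c2cn[nH]c2c1` gives 460 nM in an assay for inhibition of Tryptophan 2,3-dioxygenase (Homo sapiens), with stated times of 10 min and 60 min (a lower number here means a stronger inhibitor, a higher number a weaker inhibitor), the only numerical value in hand. Compound 1 `O=C1NCc2c(NCc3ccccc3[N+](=O)[O-])cccc21` yields no number, only a limit, > 100000 nM, which is the limit of > 100000 nM in this assay, at which 1 of the 2 values shown sits. Compound 3 `FC(F)(F)c1cc(NCc2cccc(Br)c2)c2cn[nH]c2c1` has not yet been measured; it differs from compound 2 in one place: 3-bromophenyl in place of piperidin-2-yl on a saturated chain carbon bound to a nitrogen on an aromatic ring. Among the measured compounds shown here, no measured step of this kind exists to lean on, so the change is expected to weaken binding by a modest amount, a step of a 3.3-fold higher number from compound 2 to compound 3 (0.51 log units; beyond the scatter), somewhat beyond the usual scatter. Compound 3 is therefore expected to give 1500 nM, most likely between 300 nM and 8000 nM in this assay.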

Compound 3, half-maximal inhibitory concentration: 19100 nM
Beside the measured number, compound 3's estimate is 13-fold (1.10 log units) below it; measured number outside the range, above it.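

In this assay, this place, on a saturated chain carbon bound to a nitrogen on an aromatic ring, proves sensitive to the group it carries: 3-bromophenyl in place of piperidin-2-yl gives a 42-fold higher number from compound 2 to compound 3 (1.62 log units; beyond the scatter). A six-membered ring alone is therefore not enough to keep the potency of compound 2 here. Nothing shown accounts for this loss. Because the two groups differ in several ways at once, the compounds leave open which difference matters. A cyclohexyl group or an open-chain amine at this place would help separate the ring nitrogen from the ring itself.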